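The compounds below may be only part of what the source reports. "The series", "measured", "known", "first", "only" and "open" are said of these compounds alone.

Measured so far in a functional assay on CCRF-HSB-2 cells (Homo sapiens) for antiproliferative activity; a lower number here means a stronger inhibitor, a higher number a weaker inhibitor:
- Compound 1 `O=c1[nH]c(=O)n([C@H]2S[C@H](CO)[C@@H](O)[C@@H]2O)cc1I`: > 100 ug/mL
- Compound 2 `CCc1cn([C@H]2S[C@H](CO)[C@@H](O)[C@@H]2O)c(=O)[nH]c1=O`: > 100 ug/mL
- Compound 3 `O=c1[nH]c(=O)n([C@@H]2S[C@H](CO)[C@@H](O)[C@@H]2O)cc1/C=C/Br`: > 100 ug/mL

Each of these entries is a limit of the assay and not a number. Compound 3 therefore has no exact position on the scale, and it shares (the limit of > 100 ug/mL in this assay, at which 3 of the 3 values shown sit).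

Compound 4 `O=c1[nH]c(=O)n([C@H]2S[C@H](CO)[C@@H](O)[C@@H]2O)cc1/C=C/Br` is closely related to compound 3: the two compounds have the same atoms and bonds and differ only in configuration as drawn: 1 of 5 stereo elements differ; a stereocentre at a saturated ring carbon is drawn R in compound 3 and S in compound 4. Among the compounds with values here, the only measured step is a step that the two limits leave unreadable from compound 1 to compound 2. It concerns a different change, and it has no readable size, so it offers no guide to the effect of changing configuration. Within the data shown here, with no measured step to suggest otherwise, no step beyond the scatter is expected in this assay, and no direction can be favoured. This expectation rests on compound 3, whose > 100 ug/mL is a limit.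

The estimated step is a step that the limit leaves unreadable from compound 3 to compound 4. Compound 4 is expected to come in near 120 ug/mL, with an estimated range from 40 ug/mL to 300 ug/mL.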

Compound 4, half-maximal inhibitory concentration: > 100 ug/mL
Compound 4 gave a limit, no number; the forecaster's own chance of this, stated with the estimate: 75%; the middle value lies beyond the limit too.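

In this assay no step can be read between compound 4 and compounds 1, 2 or 3, because each result is a limit and not a number: the limit of > 100 ug/mL in this assay, at which 4 of the 4 values shown sit.

The compounds shown leave open how strong any of them is, and whether the configuration differing between compound 3 and compound 4 matters.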